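Solubility Limit Holds Across Macrolide Quinoline Variants

The source may hold more compounds than are shown below. What is called first, only, known or untested is meant among the compounds shown, and "the series" means these compounds.

Three compounds share one large macrocyclic core bearing a basic sugar with a side chain. Compound 1 `CC[C@H]1OC(=O)[C@H](C)[C@@H](O[C@H]2C[C@@](C)(OC)[C@@H](O)[C@H](C)O2)[C@H](C)[C@@H](O[C@@H]2O[C@H](C)C[C@H](N(C)C)[C@H]2OCCCNC(=O)CNc2ccnc3ccccc23)[C@](C)(O)C[C@@H](C)CN(C)[C@H](C)[C@@H](O)[C@]1(C)O` gives a reading of > 10000 ug/mL in a physicochemical assay for solubility, at pH 4 (on this read-out lower numbers stand for lower solubility and higher numbers for higher solubility), which is a limit of the assay rather than a number. Compound 2 `CC[C@H]1OC(=O)[C@H](C)[C@@H](O[C@H]2C[C@@](C)(OC)[C@@H](O)[C@H](C)O2)[C@H](C)[C@@H](O[C@@H]2O[C@H](C)C[C@H](N(C)C)[C@H]2OCCCNc2ccnc3cc(Cl)ccc23)[C@](C)(O)C[C@@H](C)CN(C)[C@H](C)[C@@H](O)[C@]1(C)O` likewise reaches > 10000 ug/mL in this assay, again only a limit. Compound 3 `CC[C@H]1OC(=O)[C@H](C)[C@@H](O)[C@H](C)[C@@H](O[C@@H]2O[C@H](C)C[C@H](N(C)C)[C@H]2OCCCNc2ccnc3cc(Cl)ccc23)[C@](C)(O)C[C@@H](C)CN(C)[C@H](C)[C@@H](O)[C@]1(C)O`, which carries hydrogen in place of 5-hydroxy-4-methoxy-4,6-dimethyloxan-2-yl on an oxygen on a saturated carbon, also gives > 10000 ug/mL, a limit. The step that the two limits leave unreadable from compound 2 to compound 3 therefore cannot be read, and the three readings all sit together at the limit of > 10000 ug/mL in this assay, at which 3 of the 3 values shown sit. Compound 4 `CC[C@H]1OC(=O)[C@H](C)[C@@H](O[C@H]2C[C@@](C)(OC)[C@@H](O)[C@H](C)O2)[C@H](C)[C@@H](O[C@@H]2O[C@H](C)C[C@H](N(C)C)[C@H]2OCCCNCc2cnc3ccccc3c2)[C@](C)(O)C[C@@H](C)CN(C)[C@H](C)[C@@H](O)[C@]1(C)O` differs from compound 2 in one place: (quinolin-3-yl)methyl in place of 7-chloroquinolin-4-yl on an amine nitrogen. Among the measured compounds shown here, no measured step resolves this exchange, since the only step known is unreadable. The step of a number no higher from compound 2 to compound 4 (the limit leaves the size open) is expected to stay within the scatter. The estimate for compound 4 in this assay is 10000 ug/mL, in a range from 5000 ug/mL to 20000 ug/mL, most likely reported again as a limit.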

Compound 4, solubility: > 10000 ug/mL
Compound 4 ended at the assay's limit; the forecaster's own chance of this, stated with the estimate: 85%; the middle value sits exactly at the limit.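

Compound 4 stops at a limit in this assay just as compound 2 does, and no new step can be read between compound 2 and compound 4. The compounds shown leave open how their true solubilities compare, with every reading at one limit: the limit of > 10000 ug/mL in this assay, at which 4 of the 4 values shown sit.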